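Dimethoxyphenyl for chlorophenyl on a triazole-linked spirooxindole core

The source may hold more compounds than are shown below. What is called first, only, known or untested is meant among the compounds shown, and "the series" means these compounds.

Measured compounds, all in a functional assay on HepG2 cells (Homo sapiens) for antiproliferative activity, read by MTT assay, with a stated time of 48 h; a higher number here means a weaker inhibitor, a lower number a stronger inhibitor:
compound 1, `N#CC1=C(N)Oc2c(c3nc4ccccc4nc3c3ccccc23)C12C(=O)N(Cc1cnnn1-c1ccc(F)cc1)c1ccccc12`, gives > 50000 nM, a limit of the assay.
compound 2, `N#CC1=C(N)Oc2c(c3nc4ccccc4nc3c3ccccc23)C12C(=O)N(Cc1cnnn1-c1ccc(F)c(Cl)c1)c1ccccc12`, gives > 50000 nM, also a limit.
compound 3, `N#CC1=C(N)Oc2c(N)cc3nc4ccccc4nc3c2C12C(=O)N(Cc1cnnn1-c1ccc(Cl)cc1)c1ccccc12`, gives > 50000 nM, again a limit.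

Compound 3 therefore stands at the limit, with no number of its own; it shares this with the two other compounds, as the limit of > 50000 nM in this assay, at which 3 of the 3 values shown sit, shows. Going by the values given here, the only step between measured compounds, a step that the two limits leave unreadable from compound 1 to compound 2, changes the aryl group on the triazole nitrogen by a chloro in place of hydrogen on an aromatic carbon, but both of its ends are limits, so its size cannot be read.

Compound 4, `COc1ccc(OC)c(-n2nncc2CN2C(=O)C3(C(C#N)=C(N)Oc4c(N)cc5nc6ccccc6nc5c43)c3ccccc32)c1`, differs from compound 3 in the same region: 2,5-dimethoxyphenyl in place of 4-chlorophenyl on an aromatic nitrogen. Among the compounds with values here, no measured step gives a readable size for a change of this kind, since the one step on the aryl group is unreadable. The expected step that the limit leaves unreadable from compound 3 to compound 4 is therefore small and probably unreadable, because the limit of > 50000 nM in this assay, at which 3 of the 3 values shown sit, holds every value shown at the limit. Compound 4 is expected to give about 60000 nM, between 20000 nM and 200000 nM.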

Compound 4, half-maximal inhibitory concentration: 45100 nM
For compound 4 the middle estimate is 1.3-fold (0.12 log units) above the measured one; the measured number falls inside the stated range.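

In this assay, going by these compounds alone, compound 4 gives 45100 nM as the first value here that is a number and not a limit, which shows that a compound of this series with 2,5-dimethoxyphenyl on the aromatic nitrogen can be read in this assay. Compound 3 gives > 50000 nM as a limit of the assay. On these data alone, the change from 4-chlorophenyl to 2,5-dimethoxyphenyl gives an at least 1.1-fold lower number from compound 3 to compound 4 (0.04 log units; that floor lies within the scatter) as its only readable measure, and its true size stays unknown because one end of the step is a limit: the limit of > 50000 nM in this assay, at which 3 of the 4 values shown sit.

As far as these compounds go, it remains open whether one methoxy group alone would give a readable number, and which of the two positions would matter. From the compounds shown here alone, it is equally open how a phenyl ring carrying an amine or a carboxylic acid, or a longer alkyl chain in place of the ring, would read at this nitrogen.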